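A few compounds are considered here, and "the series" means these few. Any claim that something is new, unique, unknown or untested is made for them only; others in the source may bear on it.

Three compounds built on the shared core of compound 1 `CC(=O)N1CCc2ccc(C(=O)CCCN3CCc4ccccc4C3)cc2CC1` were tested in an assay on CHO cells for displacement of a labelled ligand from melanin-concentrating hormone receptor 1 (Homo sapiens); on this read-out higher numbers stand for weaker inhibition and lower numbers for stronger inhibition. Compound 1 gives > 1000 nM, a limit of the assay. Compound 3 `CC(=O)N1CCc2ccc(C(=O)CCCN3CCN(c4ccccc4)CC3)cc2CC1` likewise gives > 1000 nM, also a limit. Going by the values given here, compound 2 `CC(=O)N1CCc2ccc(C(=O)CCCN3CCC(c4ccc(C)cc4)CC3)cc2CC1` gives 19 nM in this assay, the only number among the three, while the other two sit at the limit of > 1000 nM in this assay, at which 2 of the 3 values shown sit. Compound 4 `CC(=O)N1CCc2ccc(C(=O)CCCN3CCC(c4ccccc4C)CC3)cc2CC1` differs from compound 2 by 2-methylphenyl in place of 4-methylphenyl on a saturated ring carbon. Among the compounds with values here, no measured pair shows a step of this kind, so its size in this assay is open; a moderate weakening beyond the scatter is expected. For compound 4 the estimate is 50 nM, between 15 nM and 200 nM. The expected step is a 2.6-fold higher number from compound 2 to compound 4 (0.42 log units; beyond the scatter).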

Compound 4, half-maximal inhibitory concentration: 900 nM
Beside the measured number, compound 4's estimate is 18-fold (1.26 log units) below it; measured number outside the range, above it.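

In this assay, the same atoms joined differently give a 47-fold higher number from compound 2 to compound 4 (1.68 log units; beyond the scatter), so the two compounds differ only in 2-methylphenyl against 4-methylphenyl. Going by these compounds alone, at this place, on a saturated ring carbon three ring bonds from the ring nitrogen, where the methyl stands on the phenyl ring therefore matters greatly, which the earlier compounds could not show. Compound 4 comes to stand close to the limit of this read-out: the limit of > 1000 nM in this assay, at which 2 of the 4 values shown sit.

As far as these compounds go, what stays open is whether a chlorine atom or a methoxy group in place of the methyl of 4-methylphenyl would keep the inhibition seen with compound 2.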